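Aryl Swap on a Ring Amine Nitrogen of Compound 2

The source may report more compounds than this note shows. Statements on the series, on what has been measured and on what is new or still open speak of the compounds shown alone.

Measured in an assay on HEK293 cells for inhibition of Voltage-dependent T-type calcium channel subunit alpha-1G (Homo sapiens), read by patch clamp; a higher number here means a weaker inhibitor, a lower number a stronger inhibitor:
- compound 2 `CCCc1nc(-c2ccccc2)c(CNCCN2CCN(c3cccc(C)c3C)CC2)o1` gives 1710 nM
- compound 3 `CCCc1nc(-c2ccccc2)c(CNCCCN2CCN(c3ccccc3Cl)CC2)o1` gives 2800 nM
- compound 1 `CCCc1nc(-c2ccccc2)c(CNCCCN2CCN(c3ccc(C(F)(F)F)cc3)CC2)o1` gives 7250 nM

Compound 2 has the lowest of the three numbers in this assay. Its nearest neighbour is compound 3, whose number sits within the scatter of that of compound 2, so no order between the two can be claimed. Compound 1 stands beyond the scatter above compound 2, with the gap between them being the largest among the three.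

Compound 4 `CCCc1nc(-c2ccccc2)c(CNCCN2CCN(c3cccc(Cl)c3)CC2)o1` is not yet measured. It differs from compound 2 in one place: 3-chlorophenyl in place of 2,3-dimethylphenyl on an amine nitrogen in a ring.

For the measured compounds named here, one measured step bears on this change. In it, one aryl group on the same kind of ring amine nitrogen was exchanged for another: a 2.6-fold lower number from compound 1 to compound 3 (0.41 log units; beyond the scatter). Going by the values given here, that step was modest, and the two aryl groups exchanged there differ from the pair exchanged here, so it shows only that such a swap can move the number by a modest amount in either direction. With compound 3 carrying a chlorophenyl and lying within the scatter of compound 2, compound 4 is expected to stay near compound 2, with a step of a 1.5-fold higher number from compound 2 to compound 4 (0.16 log units; within the scatter). Compound 4 is therefore estimated at 2500 nM, in the range 900 nM to 7000 nM.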

Compound 4, half-maximal inhibitory concentration: 1450 nM
Estimate against measurement, compound 4: 1.7-fold (0.24 log units) above; the range from low to high includes it.
By their numbers in this assay, from the lowest: compounds 4, 2 and 3 (each within the scatter of the next); then compound 1.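

In this assay, putting 3-chlorophenyl in place of 2,3-dimethylphenyl on the ring amine nitrogen gives a 1.2-fold lower number from compound 2 to compound 4 (0.07 log units; within the scatter) and so leaves the two aryl groups indistinguishable on the chain that compound 2 carries. For the compounds shown here, the only earlier aryl exchange on this kind of nitrogen, a 2.6-fold lower number from compound 1 to compound 3 (0.41 log units; beyond the scatter) on a different chain, showed a real shift, whereas this pair shows that such an exchange need not move the number measurably, even though the group leaving has 8 heavy atoms, all carbon, and the group entering has 7, one of them chlorine. Nothing measured here explains why the number holds through this exchange.

The compounds shown leave open whether a pyridine ring, or a phenyl bearing a methoxy group or a nitrile, would also stay within the scatter of compound 2 on this nitrogen. They also leave open how 3-chlorophenyl behaves on the chain of compound 3, since no pair shown isolates the effect of that chain.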